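This account rests on a few compounds, and the source may have more. Where it says the series, first, only, none or still open, it means among the compounds named here.

Measured so far:
compound 1 `CCCCOc1cc(C(C)(C)C)ccc1C/N=C(\S)NCc1ccc(NS(C)(=O)=O)cc1`: 60 nM
compound 2 `COCCOc1cc(C(C)(C)C)ccc1C/N=C(\S)NCc1ccc(NS(C)(=O)=O)cc1`: 60 nM

In a functional assay for inhibition of Vanilloid receptor (Rattus norvegicus) (on this read-out lower numbers stand for stronger inhibition and higher numbers for weaker inhibition), compound 1 gives 60 nM and compound 2 gives 60 nM. The one measured step, no change at the digits printed from compound 1 to compound 2 (within the scatter), leaves compound 2 level with compound 1 at the digits shown; this is where compound 2 stands. Compound 3 `CC(C)(C)C(=O)OCc1cc(C(C)(C)C)ccc1C/N=C(\S)NCc1ccc(NS(C)(=O)=O)cc1` differs from compound 2 by (((tert-butyl)carbonyl)oxy)methyl in place of 2-methoxyethoxy on an aromatic carbon. The step from compound 1 to compound 2 is the only one available and it changed a different part of the molecule, the far end of the chain, so it bears on the present step only loosely. For the measured compounds named here, the tolerance it showed suggests that this position accepts variation, but the exchange of the whole group on the aromatic carbon has no measured precedent here. A step of modest size, somewhat toward weaker inhibition, is expected: a 1.7-fold higher number from compound 2 to compound 3 (0.22 log units; within the scatter). Compound 3 is estimated at 100 nM, with a range from 30 nM to 400 nM.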

Compound 3, half-maximal inhibitory concentration: 70 nM
Beside the measured number, compound 3's estimate is 1.4-fold (0.15 log units) above it; low and high end bracket the measured number.
By their numbers in this assay, from the lowest: compounds 1, 2 and 3 (each within the scatter of the next).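

In this assay the exchange of 2-methoxyethoxy for (((tert-butyl)carbonyl)oxy)methyl gives a 1.2-fold higher number from compound 2 to compound 3 (0.07 log units; within the scatter) and the exchange of butoxy for the same group gives a 1.2-fold higher number from compound 1 to compound 3 (0.07 log units; within the scatter) on the same aromatic carbon. The earlier pair differed only at the far end of the chain, whereas here the whole group is replaced, with 8 heavy atoms entering for the 5 of 2-methoxyethoxy, and all three compounds remain within the scatter of one another. Nothing measured here accounts for this tolerance at the carbon ortho to a large group.

From the compounds shown here alone, all three groups on this carbon are sizeable and carry no charge, so the reach of this tolerance remains open. Whether a much smaller hydroxymethyl group, a primary amine or a carboxylic acid at this place would stay in the same range is an open question.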